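The source may report more compounds than this note shows. Statements on the series, on what has been measured and on what is new or still open speak of the compounds shown alone.

Of the compounds shown here, three sharing one core have been measured in a functional assay on DU-145 cells (Homo sapiens) for inhibition, read by trypan blue exclusion, with a stated time of 96 h; a higher number here means a weaker inhibitor of growth, a lower number a stronger inhibitor of growth. Compound 1 `COc1ccc(/C=C(/Sc2ccc(Br)cc2)C(=O)c2ccc(Br)cc2)cc1` gives 25000 nM. Compound 2 `COc1ccc(/C=C(/Sc2ccc(Br)cc2)C(=O)c2ccc(Cl)cc2)cc1` gives 50000 nM, and compound 3 `COc1ccc(/C=C(/Sc2ccc(C)cc2)C(=O)c2ccc(Cl)cc2)cc1` gives 1000 nM. Compound 2 thus stands at the highest of the three numbers: its nearest neighbour is compound 1, from which it is separated by a 2.0-fold higher number from compound 1 to compound 2 (0.30 log units; within the scatter), and its furthest is compound 3, reached by a 50-fold lower number from compound 2 to compound 3 (1.70 log units; beyond the scatter).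

Compound 4 `COc1ccccc1/C=C(/Sc1ccc(Br)cc1)C(=O)c1ccc(Cl)cc1` has not been measured. It differs from compound 2 by 2-methoxyphenyl in place of 4-methoxyphenyl on a double-bonded chain carbon bound to a double-bonded chain carbon, the change sitting on the double-bonded chain carbon rather than on either of the two rings that were varied in the measured steps. Within the data shown here, neither of those steps, the halogen exchange from compound 1 to compound 2 nor the methyl replacement from compound 2 to compound 3, touches the methoxyphenyl group, so no measured step bears directly on this change. Without such a precedent, no shift beyond the scatter is expected, and a step of no change at the digits printed from compound 2 to compound 4 (within the scatter) is estimated. Compound 4 is therefore expected to give about 50000 nM in this assay, within a range from 12000 nM to 200000 nM.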

Compound 4, concentration for 50% growth inhibition: 10000 nM
For compound 4 the middle estimate is 5.0-fold (0.70 log units) above the measured one; the whole stated range lies above it.
By their numbers in this assay, from the lowest: compound 3; then compound 4; then compounds 1 and 2 (each within the scatter of the next).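

Among these compounds, the aryl group on the double-bonded chain carbon, left unchanged among the earlier compounds, also affects the result in this assay: 2-methoxyphenyl in place of 4-methoxyphenyl gives a 5.0-fold lower number from compound 2 to compound 4 (0.70 log units; beyond the scatter) even though the two groups have the same atoms, joined differently. Growth inhibition therefore depends on the arrangement of this group as well as on the substituents varied earlier, although this step is smaller than the one produced by methyl in place of bromo, a 50-fold lower number from compound 2 to compound 3 (1.70 log units; beyond the scatter) and so does not match that change in size. No measured evidence accounts for the shift. As far as these compounds go, it remains open whether 2-methoxyphenyl would give a similar step alongside the methyl group of compound 3. From the compounds shown here alone, it is also open how a hydroxyl or dimethylamino group in place of the methoxy group would behave on this ring.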